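Urea series on the shared core: one-step note toward compound 3

The source may hold more compounds than are shown below. What is called first, only, known or untested is meant among the compounds shown, and "the series" means these compounds.

Measured so far:
compound 1, `COc1cc(Cl)cc(-c2nn(-c3cccc(NC(=O)Nc4ccc(Cl)c(C(F)(F)F)c4)c3)cc2-c2ccncc2)c1`, 74%
compound 2, `COc1cc(Cl)cc(-c2nn(-c3cccc(NC(=O)Nc4ccc(Cl)c(Cl)c4)c3)cc2-c2ccncc2)c1`, 84%

Both values come from a functional assay on 786-0 cells (Homo sapiens) for inhibition, read by sulforhodamine B assay, with a stated time of 48 h, tested at 1 uM; on this read-out lower numbers stand for a stronger effect and higher numbers for a weaker effect at the one concentration tested. Compound 2 gives the highest of the two numbers shown; its nearest neighbour is compound 1, and the step of a number 10 percentage points higher from compound 1 to compound 2 (within the scatter) is within the scatter, so no order between them is claimed.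

The next compound is compound 3, `COc1cc(Cl)cc(-c2nn(-c3cccc(NC(=O)Nc4cccc(C(F)(F)F)c4)c3)cc2-c2ccncc2)c1`, not yet measured in this assay. Against compound 2 the change is 3-(trifluoromethyl)phenyl in place of 3,4-dichlorophenyl on an amide-type nitrogen.

Among the measured compounds shown here, only one measured step bears on this. The step from compound 1 to compound 2 exchanged trifluoromethyl for chloro on an aromatic carbon of the same urea-bound phenyl and moved the read-out by a number 10 percentage points higher from compound 1 to compound 2 (within the scatter), within the scatter. Going to compound 3 reverses that exchange and additionally removes one chlorine from that phenyl; no measured pair covers the second part. The change in this assay is therefore expected to stay within the scatter, and the step estimated for compound 3 is a number 8 percentage points lower from compound 2 to compound 3 (within the scatter). Compound 3 is estimated at 76%, with a range of 60% to 92%.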

Compound 3, a percentage reported as activity, at one concentration (the size of the read-out at that concentration, not a potency): 77%
Compound 3: the middle estimate sits 1 percentage points below what was measured; the measured number falls inside the stated range.
By their numbers in this assay, from the lowest: compounds 1, 3 and 2 (each within the scatter of the next).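

In this assay, among the compounds shown here, hydrogen in place of chloro on an aromatic carbon gives a number 3 percentage points higher from compound 1 to compound 3 (within the scatter), the first measured pair that isolates this single exchange on the urea-bound phenyl. The full replacement of 3,4-dichlorophenyl by 3-(trifluoromethyl)phenyl on an amide-type nitrogen gives a number 7 percentage points lower from compound 2 to compound 3 (within the scatter), so the three phenyl groups shown lie within the scatter of one another and no order among them is claimed; at this position, these halogen-bearing and trifluoromethyl-bearing variants are not told apart by this read-out at the one concentration tested. No measurement available here explains this lack of separation.

As far as these compounds go, all three compounds keep the shared core and the urea, and each carries a chloro or trifluoromethyl group on the phenyl, so it remains open whether an unsubstituted phenyl, or a phenyl carrying a methoxy group, an amine or a carboxylic acid, would give a step beyond the scatter. Also open, from the compounds shown here alone, is whether a longer chain between the urea nitrogen and the phenyl would change the read-out.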